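This account rests on a few compounds, and the source may have more. Where it says the series, first, only, none or still open, it means among the compounds named here.

Compound 1 `CN(C)c1ncnc2[nH]cc(Sc3cccs3)c12`: 145000 nM
Compound 2 `CNc1ncnc2[nH]cc(Sc3cccs3)c12`: 132000 nM

In an ADME assay on BJ cells (Homo sapiens), read by MTT assay, with a stated time of 3 days (on this read-out lower numbers stand for stronger inhibition and higher numbers for weaker inhibition), compound 2 and compound 1 lie within the scatter of each other. Compound 3 `Cc1ncnc2[nH]cc(Sc3cccs3)c12` carries methyl in place of methylamino on an aromatic carbon of compound 2: methyl in place of methylamino on an aromatic carbon. Among the measured compounds shown here, the one measured step, a 1.1-fold lower number from compound 1 to compound 2 (0.04 log units; within the scatter), stays within the scatter, but it only puts hydrogen in place of methyl on a nitrogen. For the measured compounds named here, no measured step removes that nitrogen, so it offers weak guidance, and no shift beyond the scatter is expected. The expected step is a 1.2-fold lower number from compound 2 to compound 3 (0.08 log units; within the scatter). Compound 3 is estimated at 110000 nM, within a range of 45000 nM to 220000 nM.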

Compound 3, half-maximal inhibitory concentration: > 150000 nM
Compound 3: a limit, no number (the forecaster's own chance of this, stated with the estimate: 15%); middle value at least 1.3-fold (0.13 log units) from the limit.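

Among the compounds shown here, removing the nitrogen from this aromatic carbon, a change the earlier compounds did not include, gives an at least 1.1-fold higher number from compound 2 to compound 3 (0.05 log units; that floor lies within the scatter) and an at least 1.0-fold higher number from compound 1 to compound 3 (0.01 log units; that floor lies within the scatter) in this assay. Going by these compounds, both floors lie within the scatter, so the true size of either step stays unknown. The result for compound 3 is a limit, not a number: the limit of > 150000 nM in this assay, at which 1 of the 3 values shown sits.

On these data alone, whether a primary amine, a hydroxyl or a longer chain such as ethyl on this aromatic carbon would give a measurable number stays open. So does the effect of a carboxylic acid there.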